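A Smaller Group Replaces Trifluoromethoxy: Compound 2 to Compound 4

This account rests on a few compounds, and the source may have more. Where it says the series, first, only, none or still open, it means among the compounds named here.

Of the compounds shown here, three have been measured in an assay on isolated protein for inhibition of DNA topoisomerase 1 (Homo sapiens), with a stated time of 30 min, tested at 20 uM; on this read-out lower numbers stand for a weaker effect and higher numbers for a stronger effect at the one concentration tested. Compound 1 `COc1cccc(-c2nc3cc(C)ccc3c(=O)[nH]2)c1` gives 80%, compound 3 `CCN(CC)c1ccc2nc(-c3ccccc3C(F)(F)F)[nH]c(=O)c2c1` gives 13.3%, and compound 2 `Cc1ccc2nc(-c3cccc(OC(F)(F)F)c3)[nH]c(=O)c2c1` gives 0%, the lowest of the three and beyond the scatter from both others. Compound 4 `Cc1cccc(-c2nc3ccc(C)cc3c(=O)[nH]2)c1` has not been measured. It differs from compound 2 in one place: methyl in place of trifluoromethoxy on an aromatic carbon. Within the data shown here, no measured pair here differs in a single spot, so the size of this step can only be guessed. Compound 1, carrying methoxy rather than trifluoromethoxy, reaches 80%, though it also differs from compound 2 elsewhere. On that basis the step from compound 2 to compound 4 is expected to be a number 35 percentage points higher from compound 2 to compound 4 (beyond the scatter), upward and probably beyond the scatter. Compound 4 is estimated at 35%, within 0% to 75%.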

Compound 4, a percentage reported as inhibition, at one concentration (the size of the read-out at that concentration, not a potency): 12.7%
Beside the measured number, compound 4's estimate is 22.3 percentage points above it; the range from low to high includes it.
By their numbers in this assay, from the lowest: compound 2; then compounds 4 and 3 (each within the scatter of the next); then compound 1.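

In this assay, among these compounds, replacing trifluoromethoxy with methyl on this aromatic carbon gives a number 12.7 percentage points higher from compound 2 to compound 4 (beyond the scatter) and provides the first single-place comparison. The group at this position therefore matters: methyl restores a modest effect, whereas trifluoromethoxy leaves none at the concentration tested. Nothing available explains this difference. The compounds shown leave open how a hydroxyl group, an amine or a longer chain such as ethyl would behave on the same carbon. They also leave open whether this step would be the same size with other substituents on the shared core.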